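The source may report more compounds than this note shows. Statements on the series, on what has been measured and on what is new or still open speak of the compounds shown alone.

Measured compounds:
- compound 1 `CN(CCN(C)C(=O)n1cc(C#N)cn1)Cc1cccc(OCc2ccccc2)c1`; in an assay on membranes from brain for binding affinity to neutral cholesterol ester hydrolase 1 (Mus musculus), read by fluorescence, with stated times of 1 h and 30 min (on this read-out higher numbers stand for weaker inhibition and lower numbers for stronger inhibition), compound 1 gives > 100000 nM
- compound 2 `CN(CCN(C)C(c1ccc(OCc2ccccc2)cc1)c1ccc(OCc2ccccc2)cc1)C(=O)n1cc(C#N)cn1`; in this assay compound 2 gives > 1000000 nM
- compound 3 `Cc1cnn(C(=O)N2CCN(C(c3ccc(OCc4ccccc4)cc3)c3ccc(OCc4ccccc4)cc3)CC2)c1`; in this assay compound 3 gives > 100000 nM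

Each of these three values is a limit of the assay and not a number. Compound 3 stands at the limit of > 100000 nM in this assay, at which 2 of the 3 values shown sit, together with compound 1. Compound 2 sits at the limit of > 1000000 nM in this assay, at which 1 of the 3 values shown sits. For the measured compounds named here, no step between measured compounds can be read, since every value shown is a limit.

Compound 4 `O=C(N1CCN(C(c2ccc(OCc3ccccc3)cc2)c2ccc(OCc3ccccc3)cc2)CC1)n1cccn1` differs from compound 3 by hydrogen in place of methyl on an aromatic carbon, in words hydrogen in place of methyl on an aromatic carbon. With every measured value at a limit, no change beyond the scatter is expected in this assay; the step from compound 3 to compound 4 is estimated as a step that the limit leaves unreadable from compound 3 to compound 4. Compound 4 is expected to give about 150000 nM, in the range 50000 nM to 1000000 nM, most likely again reported only as a limit.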

Compound 4, half-maximal inhibitory concentration: > 100000 nM
Compound 4: a limit, no number (the forecaster's own chance of this, stated with the estimate: 85%); the middle value lies beyond the limit too.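

No step can be read from compound 3 to compound 4: in this assay both are reported only as limits, not numbers. The compounds shown leave open what hydrogen in place of methyl on an aromatic carbon does to inhibition, and whether any compound of this series gives a number in this assay.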